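This account rests on a few compounds, and the source may have more. Where it says the series, first, only, none or still open, it means among the compounds named here.

Compound 1 `CC(C)C[C@H](N)c1cc(C(F)(F)F)ccc1N1CCN(C(=O)C(C)Cc2ccc(Cl)cc2)CC1`: in an assay on HEK293 cells for displacement of a labelled ligand from Melanocortin receptor 4 (Homo sapiens) (on this read-out higher numbers stand for weaker inhibition and lower numbers for stronger inhibition), compound 1 gives 47 nM.
Compound 2 `CC(C)C[C@H](N)c1cc(C(F)(F)F)ccc1N1CCN(C(=O)COc2cccc(Cl)c2Cl)CC1`: in this assay compound 2 gives 2500 nM.
Compound 3 `Cc1cc(CC(C)C(=O)N2CCN(c3ccc(C(F)(F)F)cc3[C@@H](N)CC(C)C)CC2)ccc1Cl`: in this assay compound 3 gives 71 nM.

Among these three, compound 3 stands second highest. Its nearest neighbour is compound 1, with a 1.5-fold higher number from compound 1 to compound 3 (0.18 log units; within the scatter), and its furthest is compound 2, with a 35-fold lower number from compound 2 to compound 3 (1.55 log units; beyond the scatter).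

Compound 4 `CC(C)C[C@H](N)c1cc(C(F)(F)F)ccc1N1CCN(C(=O)CSc2ccc(Cl)cc2Cl)CC1` differs from compound 3 in one place: ((2,4-dichlorophenyl)sulfanyl)methyl in place of 1-(4-chloro-3-methylbenzyl)ethyl on a carbonyl carbon. Among the compounds with values here, two measured steps bear on this change. The first is a 53-fold higher number from compound 1 to compound 2 (1.73 log units; beyond the scatter), where a (2,3-dichlorophenoxy)methyl took the place of a 1-(4-chlorobenzyl)ethyl on the same carbonyl carbon; the second is a 35-fold lower number from compound 2 to compound 3 (1.55 log units; beyond the scatter), which is the same kind of exchange run the other way. Both were large. Within the data shown here, the entering group in compound 4 is again an aryl group joined through a heteroatom to a methyl on the carbonyl carbon, as in compound 2, so a large rise in the number is expected for this assay, though no measured pair separates a sulfanyl link from an oxygen link or one dichloro pattern from the other. For compound 4 the estimate is 1500 nM, between 300 nM and 6000 nM, which means an expected step of a 21-fold higher number from compound 3 to compound 4 (1.32 log units; beyond the scatter).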

Compound 4, inhibition constant: 1500 nM
Estimate against measurement, compound 4: no gap at the digits printed, and the stated range covers the measured number.
By their numbers in this assay, from the lowest: compounds 1 and 3 (each within the scatter of the next); then compounds 4 and 2 (each within the scatter of the next).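

With a sulfanyl link in place of the oxygen link, the group on the carbonyl carbon still gives a large rise in the number in this assay, both against the 1-(4-chloro-3-methylbenzyl)ethyl group (in a 21-fold higher number from compound 3 to compound 4 (1.32 log units; beyond the scatter)) and against the 1-(4-chlorobenzyl)ethyl group (in a 32-fold higher number from compound 1 to compound 4 (1.50 log units; beyond the scatter)). Replacing 2,3-dichlorophenoxy with (2,4-dichlorophenyl)sulfanyl changes the link atom and the chlorine pattern together, yet the result stays within the scatter (with a 1.7-fold lower number from compound 2 to compound 4 (0.22 log units; within the scatter)). Nothing measured here explains these differences.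

The compounds shown do not separate the link atom from the chlorine pattern, as no pair changes only one of them. They also leave open what an amine or a carboxylic acid in place of the sulfanyl link would do to the number.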